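Aryl amide swap from compound 1 to compound 4

A few compounds are considered here, and "the series" means these few. Any claim that something is new, unique, unknown or untested is made for them only; others in the source may bear on it.

Compound 1 `O=C(/C=C/C(=O)N1C/C(=C\c2ccccc2)C(=O)/C(=C/c2ccccc2)C1)Nc1ccc(Cl)c(Cl)c1` carries a 3,4-dichlorophenyl on the amide-type nitrogen of the shared core. In a functional assay on CCRF-CEM cells (Homo sapiens) for cytotoxicity (a lower number here means a stronger inhibitor, a higher number a weaker inhibitor), compound 1 gives 350 nM. Compound 2 `CC(=O)c1ccc(NC(=O)/C=C/C(=O)N2C/C(=C\c3ccc([N+](=O)[O-])cc3)C(=O)/C(=C/c3ccc([N+](=O)[O-])cc3)C2)cc1` gives 360 nM in this assay, and compound 3 `O=C(/C=C/C(=O)N1C/C(=C\c2ccc([N+](=O)[O-])cc2)C(=O)/C(=C/c2ccc([N+](=O)[O-])cc2)C1)Nc1ccc([N+](=O)[O-])cc1` gives 410 nM. All three numbers lie within the usual scatter of one another, so compound 1 is not separated from either neighbour. Among the compounds with values here, the one measured single-point step, a 1.1-fold higher number from compound 2 to compound 3 (0.06 log units; within the scatter), shows that exchanging one substituent on the aryl amide for another left the half-maximal inhibitory concentration unchanged within the scatter; compounds 2 and 3 also differ from compound 1 elsewhere in the core, so that step bears on the aryl amide position only indirectly.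

Compound 4 `Cc1ccc(NC(=O)/C=C/C(=O)N2C/C(=C\c3ccccc3)C(=O)/C(=C/c3ccccc3)C2)cc1` has not been measured. It differs from compound 1 by 4-methylphenyl in place of 3,4-dichlorophenyl on an amide-type nitrogen. Within the data shown here, no measured pair covers this exact exchange; the single step available, at the same aryl amide position, stayed within the scatter. Compound 4 is therefore expected to show a 1.3-fold higher number from compound 1 to compound 4 (0.11 log units; within the scatter), a step not beyond the scatter. Compound 4 is estimated at 450 nM, with a range from 200 nM to 1000 nM.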

Compound 4, half-maximal inhibitory concentration: 1100 nM
Beside the measured number, compound 4's estimate is 2.4-fold (0.39 log units) below it; measured number above the stated range.
By their numbers in this assay, from the lowest: compounds 1, 2 and 3 (each within the scatter of the next); then compound 4.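

The aryl amide position on the core of compound 1 is not indifferent to its substituents. In this assay, within the data shown here, 4-methylphenyl in place of 3,4-dichlorophenyl on the amide-type nitrogen gives a step beyond the scatter (a 3.1-fold higher number from compound 1 to compound 4 (0.50 log units; beyond the scatter)), whereas the only earlier step, read on the different core shared by compound 2 and compound 3, stayed within it (a 1.1-fold higher number from compound 2 to compound 3 (0.06 log units; within the scatter)). No line of measurement on the compounds shown accounts for this step, and its origin remains unassigned.

The exchange removes both chlorine atoms and brings in a methyl in a single move, so the compounds shown do not separate the contribution of the chlorine atoms from that of the methyl, and a plain phenyl, a 4-chlorophenyl or a 4-aminophenyl on the same nitrogen would be needed to place each part of the step. Whether 4-methylphenyl has a comparable effect on the core of compound 2 and compound 3 also stays open, since no pair shown makes this exchange on that core.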